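From fluoro to chloro: compound 3 to compound 4

The source may hold more compounds than are shown below. What is called first, only, known or untested is meant among the compounds shown, and "the series" means these compounds.

Measured so far in a functional assay on HUVEC cells (Homo sapiens) for antiproliferative activity, read by MTT assay, with a stated time of 24 h (a higher number here means a weaker inhibitor, a lower number a stronger inhibitor), are these compounds
compound 1 `COc1cccc(C(=O)Oc2ccc3c(=O)c(-c4cc(OC)c(OC)cc4OC)coc3c2)c1` gives > 10000 nM
compound 2 `COc1cc(OC)c(-c2coc3cc(OCC(=O)c4cccc(C(F)(F)F)c4)ccc3c2=O)cc1OC` gives > 10000 nM
compound 3 `COc1cc(OC)c(-c2coc3cc(OCc4ccc(F)cc4)ccc3c2=O)cc1OC` gives > 10000 nM

Each of these entries is a limit and not a number. Compound 3 thus stands at > 10000 nM as a limit. The series shows the limit of > 10000 nM in this assay, at which 3 of the 3 values shown sit, and so offers no ranking. Compound 4 `COc1cc(OC)c(-c2coc3cc(OCc4ccc(Cl)cc4)ccc3c2=O)cc1OC` carries chloro in place of fluoro on an aromatic carbon, para to a large group chloro in place of fluoro on an aromatic carbon and is otherwise identical to compound 3. The measured steps are a step that the two limits leave unreadable from compound 1 to compound 3 and a step that the two limits leave unreadable from compound 2 to compound 3 and neither gives a size for this change. No step beyond the scatter is therefore expected in this assay in either direction. The expected step is a step that the limit leaves unreadable from compound 3 to compound 4 and most likely the assay will again report only a limit. For compound 4 the estimate is 15000 nM with an expected range from 6000 nM to 40000 nM overall.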

Compound 4, half-maximal inhibitory concentration: 4400 nM
Estimate against measurement, compound 4: 3.4-fold (0.53 log units) above; the whole stated range lies above it.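

In this assay, going by these compounds alone, chloro in place of fluoro on an aromatic carbon, para to a large group, gives the only value shown that is a number, with an at least 2.2-fold lower number from compound 3 to compound 4 (0.35 log units; beyond the scatter). The two more distant comparisons read the same way, with an at least 2.2-fold lower number from compound 2 to compound 4 (0.35 log units; beyond the scatter) and an at least 2.2-fold lower number from compound 1 to compound 4 (0.35 log units; beyond the scatter). A change of one halogen at this place is thus enough to leave the limit that holds the other compounds: the limit of > 10000 nM in this assay, at which 3 of the 4 values shown sit.

On these data alone, the true size of each step remains open, as each starts from a limit. As far as these compounds go, whether bromo, methyl or methoxy at this place would lower the number further also remains open.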